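Aryl urea pair on a shared core: tert-butyl to trifluoromethoxy

A few compounds are considered here, and "the series" means these few. Any claim that something is new, unique, unknown or untested is made for them only; others in the source may bear on it.

Compound 1 `Cc1cc(NC(=O)Nc2ccc(C(C)(C)C)cc2)c2ccccc2n1` is the one member of this set with a numerical read-out: in an ADME assay on HepG2 cells (Homo sapiens) for cytotoxicity, with a stated time of 72 h (a higher number here means that more compound is needed for the effect, a lower number that less compound is needed), compound 1 gives 17000 nM, the only number shown. Compound 2 `CSc1ccccc1NC(=O)Nc1cc(C)nc2ccccc12` returns no number in this assay; for compound 2 the read-out is the limit > 25000 nM. Of the two values shown, one sits at that limit (the limit of > 25000 nM in this assay, at which 1 of the 2 values shown sits). For the measured compounds named here, no step between measured compounds that differ in a single place is available, so nothing measured tells how a change on the shared core moves the half-maximal effective concentration.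

Compound 3 `Cc1cc(NC(=O)Nc2ccc(OC(F)(F)F)cc2)c2ccccc2n1` is the compound still to be measured in this assay. It differs from compound 1 by trifluoromethoxy in place of tert-butyl on an aromatic carbon. Absent a measured step, the expectation is a small change, if any, within the usual scatter of this assay, with no direction favoured. The step from compound 1 to compound 3 is therefore estimated as a 1.2-fold higher number from compound 1 to compound 3 (0.07 log units; within the scatter). Compound 3 is expected to give 20000 nM in this assay, with a range of 8000 nM to 50000 nM.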

Compound 3, half-maximal effective concentration: 15000 nM
Estimate against measurement, compound 3: 1.3-fold (0.12 log units) above; the measured number falls inside the stated range.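

In this assay, for the compounds shown here, the first single-place step on the shared core is a 1.1-fold lower number from compound 1 to compound 3 (0.05 log units; within the scatter), so the two compounds cannot be told apart in this read-out. At this position, on an aromatic carbon para to a large group, a group of carbon only gives way to one carrying oxygen and fluorine, and the half-maximal effective concentration does not separate the two. The earlier compounds shown here offered no step at all, whereas this pair shows that at least one substantial change of atoms at this place leaves the number within the scatter, a finding that holds for these two groups only.

From the compounds shown here alone, compound 2 gives a limit and not a number, and steps involving it cannot be read: the limit of > 25000 nM in this assay, at which 1 of the 3 values shown sits. Still open is whether an amine or a carboxylic acid on this aromatic carbon would move the number beyond the scatter, and whether changes elsewhere on the shared core would do so.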